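A new group on the core of compound 2

This account rests on a few compounds, and the source may have more. Where it says the series, first, only, none or still open, it means among the compounds named here.

In a functional assay (aorta) with Rattus norvegicus as the target (on this read-out lower numbers stand for an effect already at smaller amounts and higher numbers for an effect only at larger amounts of compound), compound 1 `COc1ccc(-c2nc(CN)sc2-c2ccc(OC)cc2)cc1` gives 7.7 uM and compound 2 `COc1ccc(-c2nc(C(=O)N3CCCCC3)sc2-c2ccc(OC)cc2)cc1` gives 11 uM, which places the two within the scatter of each other. Compound 3 `COc1ccc(-c2nc(/C=C/C(=O)O)sc2-c2ccc(OC)cc2)cc1` is still unmeasured and differs from compound 2 as follows: 2-carboxyethenyl in place of (piperidin-1-yl)carbonyl on an aromatic carbon. Among the compounds with values here, the only measured step, a 1.4-fold higher number from compound 1 to compound 2 (0.15 log units; within the scatter), changed the group at this same place and stayed within the scatter. Within the data shown here, no measured compound carries 2-carboxyethenyl, so this guide is thin, and no shift beyond the scatter is expected in either direction. The estimate is a 1.1-fold higher number from compound 2 to compound 3 (0.04 log units; within the scatter). For compound 3 the estimated value is 12 uM, with an expected range from 3 uM to 45 uM.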

Compound 3, concentration for half-maximal effect: 55 uM
For compound 3 the middle estimate is 4.6-fold (0.66 log units) below the measured one; measured number outside the range, above it.
By their numbers in this assay, from the lowest: compounds 1 and 2 (each within the scatter of the next); then compound 3.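

The position is not indifferent to the group it carries: in this assay, 2-carboxyethenyl gives a 5.0-fold higher number from compound 2 to compound 3 (0.70 log units; beyond the scatter) and a 7.1-fold higher number from compound 1 to compound 3 (0.85 log units; beyond the scatter), both beyond the scatter, whereas aminomethyl and (piperidin-1-yl)carbonyl stayed within it. Nothing available explains this shift.

The compounds shown leave open whether the carboxylic acid or the ethenyl link goes with the higher number. A carboxylic acid placed directly on the aromatic carbon, or the methyl ester of 2-carboxyethenyl, would help to separate the two.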